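Methylation of a ring hydroxyl in a chalcone series

This account rests on a few compounds, and the source may have more. Where it says the series, first, only, none or still open, it means among the compounds named here.

The study compares three measured chalcones and one that awaits measurement. Compound 1 `COc1cc(/C=C/C(=O)c2c(OC)cc(O)c(CC=C(C)C)c2O)ccc1O`, in a functional assay on HeLa cells (Homo sapiens) for inhibition, read by MTT assay, with a stated time of 72 h (on this read-out higher numbers stand for weaker inhibition and lower numbers for stronger inhibition), gives 33800 nM. Compound 2 `COc1cc(O)c(CC=C(C)C)c(O)c1C(=O)/C=C/c1ccc(O)c(O)c1` gives 38100 nM in this assay, and compound 3 `COc1cc(O)cc(O)c1C(=O)/C=C/c1ccc(O)cc1` gives 48100 nM there. All three values sit close together; no one of them can be called stronger or weaker than another.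

Among the measured compounds shown here, the single difference between compound 2 and compound 1 is methyl in place of hydrogen on an oxygen on an aromatic ring, and in this assay it produced a 1.1-fold lower number from compound 2 to compound 1 (0.05 log units; within the scatter).

Compound 4 `COc1ccc(/C=C/C(=O)c2c(O)cc(O)cc2OC)cc1` is built from compound 3 by the same kind of change: methyl in place of hydrogen on an oxygen on an aromatic ring. The difference between the core of compound 3 and the core of compound 2 is not broken down here.

Because a 1.1-fold lower number from compound 2 to compound 1 (0.05 log units; within the scatter) was within the scatter, the same change is expected to leave compound 4 close to compound 3. The step from compound 3 to compound 4 is estimated as a 1.1-fold lower number from compound 3 to compound 4 (0.03 log units; within the scatter). Compound 4 is therefore expected to give about 45000 nM in this assay, with the range 20000 nM to 100000 nM covering the usual spread. This expectation rests on a single prior example of the change, so the range is kept wide.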

Compound 4, half-maximal inhibitory concentration: 47700 nM
The estimate for compound 4 lay 1.1-fold (0.03 log units) below the measured number; low and high end bracket the measured number.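

In this assay the change from hydroxy to methoxy gave a 1.0-fold lower number from compound 3 to compound 4 (0.00 log units; within the scatter) on the second core, so on this core too the step cannot be told from repeated measurement. Set side by side, the two steps show no readable difference between the cores, and in this small set the change carried from the core of compound 2 to the core of compound 3 with the same near-absence of effect: the same change on two cores in this assay, a 1.1-fold lower number (0.05 log units; within the scatter) from compound 2 to compound 1 and a 1.0-fold lower number (0.00 log units; within the scatter) from compound 3 to compound 4, 1.1-fold (0.05 log units) apart, within the scatter of two such steps. Among the compounds shown here, this rests on only two pairs in a single assay, so it shows that the change left the number in place on these two cores, but not that it would do so on any other core, nor on a core where the number differs clearly from those seen here.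

The compounds shown leave open whether a group other than methyl on that oxygen, such as a longer chain or a chain ending in a carboxylic acid, would move the number beyond the scatter. They also leave open how an amine in place of the hydroxy would read in this assay, since every change seen so far is the same single methyl.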